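The source may report more compounds than this note shows. Statements on the series, on what has been measured and on what is new or still open speak of the compounds shown alone.

Measured in a functional assay on A549 cells (Homo sapiens) for cytotoxicity, read by MTT assay, with a stated time of 4 days; a lower number here means a stronger inhibitor, a higher number a weaker inhibitor:
Compound 1 `COc1cc(C[C@H]2C(=O)OC[C@@H]2Cc2ccc(OC)c(OC)c2)ccc1N`: 2850 nM
Compound 2 `COc1cc(C[C@H]2C(=O)OC[C@@H]2Cc2ccc(OC)c(OC)c2)ccc1Nc1ccccc1`: > 50000 nM, a limit
Compound 3 `COc1ccc(Nc2ccc(C[C@H]3C(=O)OC[C@@H]3Cc3ccc(OC)c(OC)c3)cc2OC)cc1`: > 50000 nM, a limit

Compound 3 gives no number and stands at the limit of > 50000 nM in this assay, at which 2 of the 3 values shown sit. Compound 4 `COc1cccc(C[C@H]2C(=O)OC[C@@H]2Cc2ccc(OC)c(OC)c2)c1` carries hydrogen in place of (4-methoxyphenyl)amino on an aromatic carbon. Among the compounds with values here, two measured steps bear on this, both large: an at least 17-fold higher number from compound 1 to compound 2 (1.24 log units; beyond the scatter) and an at least 17-fold higher number from compound 1 to compound 3 (1.24 log units; beyond the scatter). Within the data shown here, compound 4 loses the added aryl ring, but it also loses the nitrogen, and no measured step covers that loss. A move toward a lower number is therefore expected, though compound 4 may also reach the limit. The expected change is an at least 2.5-fold lower number from compound 3 to compound 4 (0.39 log units; beyond the scatter). For compound 4 the estimate is 20000 nM, with an expected range of 6000 nM to 50000 nM.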

Compound 4, half-maximal inhibitory concentration: > 50000 nM
Compound 4 was reported as a limit; the forecaster's own chance of this, stated with the estimate: 40%; at least 2.5-fold (0.39 log units) between middle value and limit.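

Taking the amino group off altogether does not keep the number of compound 1 (an at least 17-fold higher number from compound 1 to compound 4 (1.24 log units; beyond the scatter)), and compound 4 stands only at a limit. Among these compounds, then, a lower number appears only with the free amino group at this position, whether that nitrogen carries an aryl ring or is gone. The steps from compound 2 and compound 3 to compound 4 cannot be read, as both ends are limits, and the series now gathers at one ceiling: the limit of > 50000 nM in this assay, at which 3 of the 4 values shown sit.

As far as these compounds go, whether the nitrogen itself matters stays open. A hydroxyl, a methylamino group or an acetamide at this position would test that.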